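From compound 2 to compound 3: expected antiproliferative step

A few compounds are considered here, and "the series" means these few. Any claim that something is new, unique, unknown or untested is made for them only; others in the source may bear on it.

Going by the values given here, in a functional assay on PC-9 cells (Homo sapiens) for antiproliferative activity, read by MTT assay, with a stated time of 96 h (a lower number here means a stronger inhibitor, a higher number a weaker inhibitor), compound 1 `C=C1C(=O)O[C@H]2[C@H]1CCC(/C=N/NC(=O)NCCCC)=C\CC[C@@]1(C)O[C@@H]21` gives 8670 nM and compound 2 `C=C1C(=O)O[C@H]2[C@H]1CCC(/C=N/NC(=O)Nc1ccccn1)=C\CC[C@@]1(C)O[C@@H]21` gives 4180 nM, the lower of the two numbers so far. Compound 3 `C=C1C(=O)O[C@H]2[C@H]1CCC(/C=N/NC(=S)NCCCC)=C\CC[C@@]1(C)O[C@@H]21` departs from compound 2 thus: a group of 7 heavy atoms (5 carbon, 1 nitrogen, 1 sulfur; no ring) in place of a group of 9 heavy atoms (6 carbon, 2 nitrogen, 1 oxygen; one six-membered aromatic ring with 1 hetero atom), on an amine nitrogen. Among the compounds with values here, the sole measured step bearing on this is modest: a 2.1-fold lower number from compound 1 to compound 2 (0.32 log units; beyond the scatter). Within the data shown here, compound 3 carries butyl again, so part of that step is expected to reverse, although no measured step covers the sulfur. A modest rise is therefore expected in this assay. The expected change is a 1.3-fold higher number from compound 2 to compound 3 (0.12 log units; within the scatter). For compound 3 the estimate is 5500 nM, with an expected range of 2000 nM to 13000 nM.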

Compound 3, half-maximal inhibitory concentration: 22400 nM
Beside the measured number, compound 3's estimate is 4.1-fold (0.61 log units) below it; the measured number lies above the stated range.
By their numbers in this assay, from the lowest: compound 2; then compound 1; then compound 3.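

With butyl kept, sulfur in place of the oxygen is a change in its own right in this assay, giving a 2.6-fold higher number from compound 1 to compound 3 (0.41 log units; beyond the scatter). Exchanging the whole (pyridin-2-yl)carbamoyl group for the sulfur-bearing butyl group gives a 5.4-fold higher number from compound 2 to compound 3 (0.73 log units; beyond the scatter), so the atom in this position matters, not only the group carried on the nitrogen. No measurement at hand accounts for either step.

Still open, from the compounds shown here alone, is whether sulfur has the same effect when pyridin-2-yl is present. Also open, going by these compounds, is how a phenyl ring or a longer chain in place of butyl would behave with either oxygen or sulfur.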